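Carbamate-to-amide swap on the shared core: Emax notes

A few compounds are considered here, and "the series" means these few. Any claim that something is new, unique, unknown or untested is made for them only; others in the source may bear on it.

Measured so far:
- compound 1, `CC(C)(C)OC(=O)N1CCC(O[C@H]2CC[C@@H](Oc3ccc(S(C)(=O)=O)cc3)CC2)CC1`: 120%
- compound 2, `CC(C)(C)OC(=O)N1CCC(O[C@H]2CC[C@H](Oc3ccc(S(C)(=O)=O)c(F)c3)CC2)CC1`: 106%
- compound 3, `CC1(OC(=O)N2CCC(O[C@H]3CC[C@H](Oc4cnc(S(C)(=O)=O)cn4)CC3)CC2)CC1`: 118%

All three compounds were read in a functional assay on isolated protein for agonist activity at Glucose-dependent insulinotropic receptor (Homo sapiens), read by HTRF and cAMP accumulation; on this read-out lower numbers stand for smaller maximal responses and higher numbers for larger maximal responses. Compound 3 stands second highest of the three numbers. Its nearest neighbour is compound 1, whose value lies a little higher but within the usual scatter, so the two cannot be ordered. Compound 2 lies furthest from compound 3, a gap beyond the scatter, with compound 2 the lower of the pair.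

Compound 4, `CS(=O)(=O)c1cnc(O[C@H]2CC[C@H](OC3CCN(C(=O)C4(C(F)(F)F)CC4)CC3)CC2)cn1`, has not yet been measured in this assay. It differs from compound 3 in one place: 1-(trifluoromethyl)cyclopropyl in place of (1-methylcyclopropyl)oxy on a carbonyl carbon. The rest of the shared core is unchanged.

Among the compounds with values here, no step between two measured compounds isolates this change, so no measured anchor exists for it. Every measured compound reaches a full or above-full maximal response, so a step from compound 3 to compound 4 of a number 6 percentage points lower from compound 3 to compound 4 (within the scatter) is expected, that is, none beyond the scatter. Compound 4 is therefore estimated at 112%, with a range from 95% to 128%.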

Compound 4, largest response reached (Emax), in percent of the reference or control that the assay uses: 107%
Beside the measured number, compound 4's estimate is 5 percentage points above it, and the stated range covers the measured number.
By their numbers in this assay, from the lowest: compounds 2 and 4 (each within the scatter of the next); then compounds 3 and 1 (each within the scatter of the next).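

In this assay, within the data shown here, 1-(trifluoromethyl)cyclopropyl in place of (1-methylcyclopropyl)oxy on a carbonyl carbon gives a number 11 percentage points lower from compound 3 to compound 4 (beyond the scatter), the first single-place step. The group on this carbonyl therefore affects the maximal response, although the change from carbamate to amide still leaves compound 4 at 107%, a substantial response. Nothing available here accounts for the size or direction of this step.

The step swaps the oxygen link and adds the trifluoromethyl group at once, so the share of each remains unresolved; a 1-methylcyclopropyl group placed directly on the carbonyl would separate the two. From the compounds shown here alone, whether the same swap gives a similar step on the core of compound 1 or compound 2 also remains open.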